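The source may report more compounds than this note shows. Statements on the series, on what has been measured and on what is new or still open speak of the compounds shown alone.

Measured in a functional assay on PC-3 cells (Homo sapiens) for antiproliferative activity, read by MTT assay, with a stated time of 72 h; on this read-out higher numbers stand for weaker inhibition and lower numbers for stronger inhibition:
Compound 1 `C#CCSc1nc(Sc2ccccn2)c(C#N)c(-c2cc(OC)c(OC)c(OC)c2)n1`: > 10000 nM, a limit of the assay.
Compound 2 `C#CCSc1nc(Sc2nncs2)c(C#N)c(-c2cc(OC)c(OC)c(OC)c2)n1`: 10300 nM.

Going by the values given here, compound 2 holds the only actual number so far. Compound 3 `C#CCSc1nc(Sc2nc[nH]n2)c(C#N)c(-c2cc(OC)c(OC)c(OC)c2)n1` differs from it as follows: 1H-1,2,4-triazol-3-yl in place of 1,3,4-thiadiazol-2-yl on a sulfur. Among the compounds with values here, the one measured step, a step that the limit leaves unreadable from compound 1 to compound 2, is also a change on a sulfur, but it has no readable size to carry over. No step beyond the scatter is therefore expected in this assay, and no direction can be assigned. The expected step is a 1.0-fold lower number from compound 2 to compound 3 (0.01 log units; within the scatter). For compound 3 the estimated value is 10000 nM, with an expected range of 4000 nM to 25000 nM.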

Compound 3, half-maximal inhibitory concentration: > 20000 nM
Compound 3: only a limit was reported (the forecaster's own chance of this, stated with the estimate: 50%); middle value at least 2.0-fold (0.30 log units) away from the limit.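

In this assay compound 3 gives > 20000 nM, which is a limit of the assay. Going by these compounds alone, the change to 1H-1,2,4-triazol-3-yl on a sulfur gives the only step at this position with a readable floor, an at least 1.9-fold higher number from compound 2 to compound 3 (0.28 log units; that floor lies within the scatter), so this swap shows no gain in inhibition. The steps involving compound 1 cannot be read.

Going by these compounds, how far compound 3 lies beyond its limit stays open: the limit of > 20000 nM in this assay, at which 1 of the 3 values shown sits. Also open is whether a non-aromatic group on this sulfur, such as an aminoethyl chain or a carboxymethyl group, would give readable values.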